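Para-Substituent Swap at the Styryl Ring: Triazolyl to Methoxy

A few compounds are considered here, and "the series" means these few. Any claim that something is new, unique, unknown or untested is made for them only; others in the source may bear on it.

Measured compounds:
compound 1 `C(=C1\CCCN=C1c1cccnc1)\c1ccccc1` gives 850 nM in an assay on membranes from brain for displacement of a labelled ligand from Neuronal acetylcholine receptor; alpha4/beta2 (Rattus norvegicus), with a stated time of 3 h; a lower number here means a stronger inhibitor, a higher number a weaker inhibitor
compound 2 `CCCCOc1ccc(/C=C2\CCCN=C2c2cccnc2)cc1` gives 1960 nM in this assay
compound 3 `C(=C1\CCCN=C1c1cccnc1)\c1ccc(-n2ccnn2)cc1` gives 520 nM in this assay

Compound 3 has the lowest number of the three in this assay, though its gap to compound 1 sits within the scatter; only its gap to compound 2 is clearly beyond it. Compound 4 `COc1ccc(/C=C2\CCCN=C2c2cccnc2)cc1` differs from compound 3 by methoxy in place of 1H-1,2,3-triazol-1-yl on an aromatic carbon. Among the measured compounds shown here, two steps bear on this change: a 3.8-fold lower number from compound 2 to compound 3 (0.58 log units; beyond the scatter) and a 2.3-fold higher number from compound 1 to compound 2 (0.36 log units; beyond the scatter). Methoxy is a shorter chain than butoxy, so compound 4 is expected to land between compound 1 and compound 2, meaning a modest rise in the number. Compound 4 is therefore estimated at 1300 nM, range 600 nM to 2800 nM, corresponding to an expected step of a 2.5-fold higher number from compound 3 to compound 4 (0.40 log units; beyond the scatter).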

Compound 4, inhibition constant: 490 nM
Compound 4: the middle estimate sits 2.7-fold (0.42 log units) above what was measured; the measured number lies below the stated range.
By their numbers in this assay, from the lowest: compounds 4, 3 and 1 (each within the scatter of the next); then compound 2.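

In this assay, methoxy in place of 1H-1,2,3-triazol-1-yl on this aromatic carbon leaves the number within the scatter (a 1.1-fold lower number from compound 3 to compound 4 (0.03 log units; within the scatter)), and the same holds for methoxy in place of hydrogen (a 1.7-fold lower number from compound 1 to compound 4 (0.24 log units; within the scatter)). Only butoxy stands apart, since shortening that chain to methoxy gives a step beyond the scatter (a 4.0-fold lower number from compound 2 to compound 4 (0.60 log units; beyond the scatter)). No evidence available here gives a reason for this result.

As far as these compounds go, whether the number climbs gradually from methoxy to butoxy remains open, and ethoxy or propoxy could settle that. From the compounds shown here alone, how a hydroxyl or an amine would behave at this place also remains open.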